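This account rests on a few compounds, and the source may have more. Where it says the series, first, only, none or still open, it means among the compounds named here.

In a functional assay on EBC-1 cells (Homo sapiens) for antiproliferative activity, with a stated time of 72 h (on this read-out higher numbers stand for weaker inhibition and lower numbers for stronger inhibition), two compounds with a shared core have been measured so far. Compound 1 `N#Cc1ccc(-c2cc(F)c3ncc(Cc4ccc5ncccc5c4)n3c2)cc1F` carries a nitrile, and compound 1 gives 145 nM in this test. Compound 2 `O=C(c1ccc(-c2cc(F)c3ncc(Cc4ccc5ncccc5c4)n3c2)cc1F)N1CCC2(COC2)C1` has a larger amide group in place of that nitrile, and compound 2 gives 406 nM and so holds the higher of the two numbers, which makes it the weaker inhibitor of the pair. Compound 3 `CN1CCN(C(=O)c2ccc(-c3cc(F)c4ncc(Cc5ccc6ncccc6c5)n4c3)cc2F)CC1` has not been measured yet. It differs from compound 2 only on the carbonyl carbon, where the change is a group of 7 heavy atoms (5 carbon, 2 nitrogen; one six-membered non-aromatic ring with 2 hetero atoms) in place of a group of 8 heavy atoms (6 carbon, 1 nitrogen, 1 oxygen; one four-membered non-aromatic ring with 1 hetero atom, one five-membered non-aromatic ring with 1 hetero atom), on a carbonyl carbon and the group that enters is 4-methylpiperazin-1-yl. For the measured compounds named here, the only measured step that bears on this is a 2.8-fold higher number from compound 1 to compound 2 (0.45 log units; beyond the scatter) and it is modest. Going by the values given here, that step swapped a small group for a far larger one, whereas here the two groups are close in size, and no measured pair differs on the carbonyl carbon itself. In this assay no change beyond the scatter is therefore expected, and the expected step is a 1.2-fold lower number from compound 2 to compound 3 (0.06 log units; within the scatter) on present evidence. The estimate for compound 3 is 350 nM with an expected range of 120 nM to 1000 nM for its result.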

Compound 3, half-maximal inhibitory concentration: 869 nM
Compound 3: middle estimate off by 2.5-fold (0.39 log units), on the low side, and the stated range covers the measured number.
By their numbers in this assay, from the lowest: compound 1; then compound 2; then compound 3.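

In this assay, the group on the carbonyl carbon clearly matters: the step is a 2.1-fold higher number from compound 2 to compound 3 (0.33 log units; beyond the scatter), even though the two groups are close in heavy-atom count, and each has no hydrogen-bond donor, one hydrogen-bond acceptor and no net charge. Compound 2 and compound 3 both give higher numbers than the nitrile compound 1, and replacing cyano with (4-methylpiperazin-1-yl)carbonyl on the aromatic carbon gives a 6.0-fold higher number from compound 1 to compound 3 (0.78 log units; beyond the scatter), so neither amide shown matches the inhibition of compound 1. Nothing available explains why one amide group gives a higher number than the other.

On these data alone, it remains open whether any group on this carbonyl carbon can bring the number back down to that of compound 1, which gives 145 nM; a small dimethylamino group or a morpholin-4-yl ring would test this. As far as these compounds go, it is also open what part the methyl group of 4-methylpiperazin-1-yl plays, and a comparison with piperazin-1-yl, which has a hydrogen in its place, would help to answer that.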